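This account rests on a few compounds, and the source may have more. Where it says the series, first, only, none or still open, it means among the compounds named here.

Measured compounds:
- compound 1 `Nc1cc(Cc2ccn(Cc3cccc(Oc4cccc5c4CNC5)c3)n2)c2nn[nH]c2n1`: 1700 nM
- compound 2 `Nc1cc(Cc2ccn(Cc3ccccc3)n2)c2nn[nH]c2n1`: 2300 nM
- compound 3 `Nc1cc(Cc2ccn(Cc3cccc(C4CCNCC4)c3)n2)c2nn[nH]c2n1`: 21000 nM

All three share one core and differ only in the substituent on the benzyl ring. In an assay on cells for inhibition of thyroid peroxidase (Homo sapiens), with stated times of 10 min and 15 min (on this read-out higher numbers stand for weaker inhibition and lower numbers for stronger inhibition), compound 3 gives the highest number of the three: a 9.1-fold higher number from compound 2 to compound 3 (0.96 log units; beyond the scatter) and a 12-fold higher number from compound 1 to compound 3 (1.09 log units; beyond the scatter), both beyond the scatter, while a 1.4-fold higher number from compound 1 to compound 2 (0.13 log units; within the scatter) lies within it. So the piperidin-4-yl group is the one change in this set that clearly weakens inhibition.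

Compound 4 `Nc1cc(Cc2ccn(Cc3cccc(O[C@H]4CCNC4)c3)n2)c2nn[nH]c2n1` carries the change ((pyrrolidin-3-yl)oxy in place of piperidin-4-yl on an aromatic carbon); the new group sits on an aromatic carbon of the six-membered carbon-only ring, meta to a large group. Among the compounds with values here, two measured steps bear on it. The step from compound 2 to compound 3 shows what attaching the piperidin-4-yl costs, and the step from compound 1 to compound 3 shows that an oxygen-linked group at the same place gives a much lower number. Compound 4 also links its ring through oxygen, so the expectation is that the piperidinyl penalty is largely reversed, with the step of a 6.0-fold lower number from compound 3 to compound 4 (0.78 log units; beyond the scatter) expected to be downward and beyond the scatter, though not necessarily all the way back to compound 1. Compound 4 is therefore estimated at 3500 nM, with a range from 1200 nM to 12000 nM in this assay.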

Compound 4, half-maximal inhibitory concentration: 14000 nM
The estimate for compound 4 lay 4.0-fold (0.60 log units) below the measured number; measured number above the stated range.
By their numbers in this assay, from the lowest: compounds 1 and 2 (each within the scatter of the next); then compounds 4 and 3 (each within the scatter of the next).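

The oxygen link does not by itself recover inhibition at this place on the six-membered carbon-only ring: in this assay, (pyrrolidin-3-yl)oxy in place of piperidin-4-yl gives a 1.5-fold lower number from compound 3 to compound 4 (0.18 log units; within the scatter), so these two groups cannot be told apart on this read-out. Both ring amines therefore sit on the weak side, and the new group in place of hydrogen gives a 6.1-fold higher number from compound 2 to compound 4 (0.78 log units; beyond the scatter), a loss that an oxygen-linked group does not automatically avoid. The larger group on the same oxygen separates the two ether compounds, with an 8.2-fold higher number from compound 1 to compound 4 (0.92 log units; beyond the scatter), which ties the low number of compound 1 to what the oxygen carries rather than to the oxygen itself, though no evidence at hand accounts for any of these steps.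

The compounds shown leave open whether the ring nitrogen drives the loss, which a phenoxy or tetrahydropyran-4-yloxy group at this place would address. They also leave open whether the defined stereocentre of compound 4 matters, a question for the opposite (pyrrolidin-3-yl)oxy enantiomer.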